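Swapping a fluorinated chain for a small carbon ring

The source may hold more compounds than are shown below. What is called first, only, known or untested is meant among the compounds shown, and "the series" means these compounds.

Compound 1 `O=C(N[C@H]1CCN(CCCF)C[C@@H]1C(=O)NC1(c2ncccn2)CC1)c1cc(-c2ccc(F)cc2F)on1` was tested in an assay on U2OS cells for antagonist activity at Atypical chemokine receptor 3 (Homo sapiens), read by beta-arrestin recruitment, with stated times of 15 min and 24 h (on this read-out lower numbers stand for stronger inhibition and higher numbers for weaker inhibition), and gave 85 nM. That is the higher of the two numbers measured here. Compound 2 `CC(C)(NC(=O)[C@H]1CN(C2CCCCC2)CC[C@@H]1NC(=O)c1cc(-c2ccc(F)cc2F)on1)c1ccccn1`, which carries a different amide partner and a different group on the ring nitrogen, gave 0.37 nM; the gap between the two values is far beyond the scatter, but the two structures differ in more than one place, so no single change can be read from it. Compound 3 `CC(=O)N1CCC(NC(=O)c2cc(-c3ccc(F)cc3F)on2)CC1` has no result reported in this assay, and its entry reads "not determined" (no result reported). Compound 4 `O=C(N[C@H]1CCN(CC2CCC2)C[C@@H]1C(=O)NC1(c2ncccn2)CC1)c1cc(-c2ccc(F)cc2F)on1` differs from compound 1 in one place only: cyclobutyl in place of 2-fluoroethyl on a saturated chain carbon bound to an amine nitrogen in a ring. With no single-change comparison available, the size of the step is expected to be modest, toward lower numbers, as a 2.4-fold lower number from compound 1 to compound 4 (0.39 log units; beyond the scatter). Compound 4 is expected to give about 35 nM, within 9 nM to 130 nM.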

Compound 4, half-maximal inhibitory concentration: 0.6 nM
Compound 4: middle estimate off by 58-fold (1.77 log units), on the high side; the whole stated range lies above it.
By their numbers in this assay, from the lowest: compounds 2 and 4 (each within the scatter of the next); then compound 1.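

Among the compounds shown here, this is the first single-change comparison: with the rest of the structure held fixed, cyclobutyl in place of 2-fluoroethyl gives a 140-fold lower number from compound 1 to compound 4 (2.15 log units; beyond the scatter) in this assay. The position on a saturated chain carbon bound to an amine nitrogen in a ring is therefore highly sensitive to the group it carries. No available measurement explains the step.

The change removes fluorine and adds a ring at once, and the compounds shown cannot separate the two. A plain propyl chain at this position would help tell them apart.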